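Substituent change on the fused core: cytotoxicity notes

The source may report more compounds than this note shows. Statements on the series, on what has been measured and on what is new or still open speak of the compounds shown alone.

Measured so far:
compound 1 `O=c1ccc2nc(-c3ccccc3)nn(-c3ccccc3)c-2c1`: 230 nM in an ADME assay on GM00637 cells (Homo sapiens) for cytotoxicity, read by MTT assay, with a stated time of 72 h; a lower number here means a stronger inhibitor, a higher number a weaker inhibitor
compound 2 `Nc1cc2nc(-c3ccccc3)nn(-c3ccccc3)c-2cc1=O`: 2040 nM in this assay
compound 3 `O=c1cc2n(-c3ccccc3)nc(-c3ccccc3)nc-2cc1N1CCCC1`: 1790 nM in this assay

Compound 3 stands second highest of the three numbers; compound 2 is nearest, with a 1.1-fold lower number from compound 2 to compound 3 (0.06 log units; within the scatter), and compound 1 is furthest, with a 7.8-fold higher number from compound 1 to compound 3 (0.89 log units; beyond the scatter).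

Compound 4 `COc1cc2nc(-c3ccccc3)nn(-c3ccccc3)c-2cc1=O` differs from compound 3 by methoxy in place of pyrrolidin-1-yl on an aromatic carbon. Going by the values given here, the steps that bear on this are those placing a group on this carbon: an 8.9-fold higher number from compound 1 to compound 2 (0.95 log units; beyond the scatter) and a 7.8-fold higher number from compound 1 to compound 3 (0.89 log units; beyond the scatter), both modest and beyond the scatter, while a 1.1-fold lower number from compound 2 to compound 3 (0.06 log units; within the scatter) stays within the scatter. Two unlike groups at this carbon gave near the same number, so compound 4 is expected to sit close to compound 3, with a 1.5-fold lower number from compound 3 to compound 4 (0.17 log units; within the scatter) expected to stay within the scatter or, at most, a small step toward compound 1. Compound 4 is therefore estimated at 1200 nM, in the range 400 nM to 3500 nM.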

Compound 4, half-maximal inhibitory concentration: > 5000 nM
Compound 4 was reported as a limit; the forecaster's own chance of this, stated with the estimate: 5%; at least 4.1-fold (0.61 log units) between middle value and limit.
By their numbers in this assay, from the lowest: compound 1; then compounds 3 and 2 (each within the scatter of the next). At a limit, above all of these: compound 4.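

In this assay compound 4 is reported only as a limit, > 5000 nM. The group on this aromatic carbon therefore matters beyond the earlier picture: amino and pyrrolidin-1-yl sat within the scatter of each other, yet methoxy parts from both, with an at least 2.7-fold higher number from compound 3 to compound 4 (0.44 log units; beyond the scatter) and an at least 2.4-fold higher number from compound 2 to compound 4 (0.38 log units; beyond the scatter). Set against hydrogen on this carbon, the change is large, with an at least 21-fold higher number from compound 1 to compound 4 (1.33 log units; beyond the scatter).

As far as these compounds go, how far compound 4 lies past that limit stays open: the limit of > 5000 nM in this assay, at which 1 of the 4 values shown sits. Also open is whether a carboxylic acid, a longer alkoxy chain or an acyclic dialkylamine on this carbon would track methoxy or amino.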